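Shifting a Trifluoromethyl Group Along a Benzylsulfanyl Chain

A few compounds are considered here, and "the series" means these few. Any claim that something is new, unique, unknown or untested is made for them only; others in the source may bear on it.

Compound 1 `Cc1cc(-c2ccccc2)n(/C(N)=N/S(=O)(=O)c2cc(C)c(Cl)cc2SCc2ccccc2C(F)(F)F)n1` stands highest of the two compounds measured in an ADME assay on microsomes from liver (Homo sapiens) for metabolic stability, read by LC-MS, using NADPH, tested at 5 uM (on this read-out lower numbers stand for a shorter-lived compound and higher numbers for a longer-lived compound), where compound 1 gives 0.306 h. Compound 2 `Cc1cc(S(=O)(=O)/N=C(\N)n2nccc2-c2ccccc2)c(SCc2ccccc2C)cc1Cl` shares much of the same framework, and in this assay compound 2 gives 0.0802 h, a gap that lies beyond the usual scatter of such measurements. Compound 3 `Cc1cc(-c2ccccc2)n(/C(N)=N/S(=O)(=O)c2cc(C)c(Cl)cc2SCc2cccc(C(F)(F)F)c2)n1` has not yet been measured. It differs from compound 1 only in where the trifluoromethyl group sits: 3-(trifluoromethyl)phenyl in place of 2-(trifluoromethyl)phenyl on a saturated chain carbon bound to a sulfur. Among the measured compounds shown here, no measured pair of compounds shows this change, so its effect can only be expected, not read off. A modest step downward, a 1.4-fold lower number from compound 1 to compound 3 (0.14 log units; within the scatter), is expected, and it may well stay within the scatter. In this assay compound 3 is therefore estimated to give 0.22 h, with a likely range from 0.1 h to 0.45 h.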

Compound 3, half-life: 0.169 h
For compound 3 the middle estimate is 1.3-fold (0.11 log units) above the measured one; low and high end bracket the measured number.
By their numbers in this assay, from the lowest: compound 2; then compounds 3 and 1 (each within the scatter of the next).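

Among the compounds shown here, this is the first pair of compounds that differ only in where the trifluoromethyl group sits, and in this assay the change gives a 1.8-fold lower number from compound 1 to compound 3 (0.26 log units; within the scatter). The half-life therefore does not separate 2-(trifluoromethyl)phenyl from 3-(trifluoromethyl)phenyl on a saturated chain carbon bound to a sulfur, so this one move of the group leaves the read-out within its usual noise. No evidence is available to explain this result.

The compounds shown leave open whether the half-life at this place responds to a different group, such as a nitrile, a methoxy group or an amine in place of the trifluoromethyl group. They also leave open whether a longer chain between the sulfur and the ring would alter the half-life in this assay.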